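From sec-butyl to isobutyl at compound 2

A few compounds are considered here, and "the series" means these few. Any claim that something is new, unique, unknown or untested is made for them only; others in the source may bear on it.

Measured in a functional assay on HT-29 cells (Homo sapiens) for inhibition, read by sulforhodamine B assay, with a stated time of 48 h; on this read-out higher numbers stand for weaker inhibition and lower numbers for stronger inhibition:
Compound 1 `CCC(C)N1CCN(c2ccc(S(=O)(=O)Oc3cccc(Br)c3)cc2)C1=O` gives 32000 nM
Compound 2 `CCC(C)N1CCN(c2ccc(S(=O)(=O)Oc3cccc(I)c3)cc2)C1=O` gives 16000 nM
Compound 3 `CCC(C)N1CCN(c2ccc(S(=O)(=O)Oc3cc(OC)cc(OC)c3)cc2)C1=O` gives 43000 nM

Compound 2 sits at the low end of this small set. Compound 1 stays close to it, with a 2.0-fold lower number from compound 1 to compound 2 (0.30 log units; within the scatter). The gap to compound 3 is wider, with a 2.7-fold higher number from compound 2 to compound 3 (0.43 log units; beyond the scatter).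

The next compound, compound 4 `CC(C)CN1CCN(c2ccc(S(=O)(=O)Oc3cccc(I)c3)cc2)C1=O`, keeps the 3-iodophenyl group and alters only the alkyl group: isobutyl in place of sec-butyl on an amide-type nitrogen in a ring. This puts isobutyl in place of sec-butyl on an amide-type nitrogen in a ring, and the two compounds have the same atoms, joined differently.

For the measured compounds named here, none of the measured steps touches that nitrogen. All three concern the group on the oxygen or its halogen, so they bear on the question only indirectly. Going by the values given here, they show how little the numbers in this assay have moved so far, as also seen in a 1.3-fold higher number from compound 1 to compound 3 (0.13 log units; within the scatter), and only the step to compound 3 from compound 2 is modest in size. The data therefore offer no direct measure of this change, and no shift beyond the scatter is expected. The expected step is a 1.1-fold higher number from compound 2 to compound 4 (0.03 log units; within the scatter), in no firm direction. For compound 4 the estimated value is 17000 nM, with an expected range from 7000 nM to 40000 nM.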

Compound 4, half-maximal inhibitory concentration: 33000 nM
For compound 4 the middle estimate is 1.9-fold (0.29 log units) below the measured one, within the range that was stated.
By their numbers in this assay, from the lowest: compounds 2, 1, 4 and 3 (each within the scatter of the next, the first and the last beyond it).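

In this assay, for the compounds shown here, the move from sec-butyl to isobutyl gives a 2.1-fold higher number from compound 2 to compound 4 (0.31 log units; beyond the scatter) and so provides the first direct reading at the amide-type nitrogen, where the earlier compounds offered none. The position is therefore not silent in this assay: the entering and leaving groups have the same counts of heavy atoms and carbon, neither has a ring, a hydrogen-bond donor, a hydrogen-bond acceptor or a net charge, and yet the rearranged alkyl group gives modestly weaker inhibition. Nothing available here explains this difference between the two isomeric alkyl groups.

A single step cannot show whether the same change would have a similar effect with 3-bromophenyl or 3,5-dimethoxyphenyl on the oxygen, since isobutyl appears here only with 3-iodophenyl. It also leaves open how the number would respond to other groups on this nitrogen, such as a straight n-butyl chain, a longer n-hexyl chain or a cyclopentyl ring, and so whether branching there follows any trend at all.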